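Cytotoxicity notes: aryl swap on a nucleoside core

A few compounds are considered here, and "the series" means these few. Any claim that something is new, unique, unknown or untested is made for them only; others in the source may bear on it.

Measured compounds in an ADME assay on MRC5 cells (Homo sapiens), read by MTT assay, with a stated time of 72 h; on this read-out lower numbers stand for stronger inhibition and higher numbers for weaker inhibition:
- compound 1 `Nc1nc(N)c2c(-c3ccsc3)cn([C@@H]3O[C@H](CO)[C@@H](O)[C@H]3O)c2n1`: > 100000 nM
- compound 2 `Nc1nc(N)c2c(-c3ccoc3)cn([C@@H]3O[C@H](CO)[C@@H](O)[C@H]3O)c2n1`: > 100000 nM

Compound 1 `Nc1nc(N)c2c(-c3ccsc3)cn([C@@H]3O[C@H](CO)[C@@H](O)[C@H]3O)c2n1` carries a thiophen-3-yl group on the shared core. In this assay compound 1 returns only a limit, > 100000 nM, not a number. Compound 2 `Nc1nc(N)c2c(-c3ccoc3)cn([C@@H]3O[C@H](CO)[C@@H](O)[C@H]3O)c2n1` carries furan-3-yl in the same place. In this assay compound 2 likewise returns only a limit, > 100000 nM. The step that the two limits leave unreadable from compound 1 to compound 2 is therefore unreadable, since both ends sit at the same ceiling (the limit of > 100000 nM in this assay, at which 2 of the 2 values shown sit). Compound 2 thus stands at the limit of what this assay can report, with nothing to rank it against.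

Compound 3 `Nc1nc(N)c2c(-c3cc4ccccc4o3)cn([C@@H]3O[C@H](CO)[C@@H](O)[C@H]3O)c2n1` is not yet measured. It differs from compound 2 as follows: 1-benzofuran-2-yl in place of furan-3-yl on an aromatic carbon. Going by the values given here, the only step at hand, from compound 1 to compound 2, gives no readable size, so no direction can be drawn from it. The expectation for compound 3 in this assay is a step of an at least 1.2-fold lower number from compound 2 to compound 3 (0.09 log units; that floor lies within the scatter), that is, no change beyond scatter, with a fair chance of another limit. The estimate for compound 3 is 80000 nM, ranging from 25000 nM to 250000 nM.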

Compound 3, half-maximal inhibitory concentration: 78500 nM
Compound 3: the middle estimate sits 1.0-fold (0.01 log units) above what was measured; the measured number falls inside the stated range.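

In this assay, going by these compounds alone, the position on the aromatic carbon of the five-membered ring now yields a number for the first time, which the thiophen-3-yl and furan-3-yl groups did not give, and compound 3 with its 1-benzofuran-2-yl group gives 78500 nM. Within the data shown here, replacing furan-3-yl gives an at least 1.2-fold lower number from compound 2 to compound 3 (0.10 log units; that floor lies within the scatter), and replacing thiophen-3-yl gives an at least 1.2-fold lower number from compound 1 to compound 3 (0.10 log units; that floor lies within the scatter); both are floors rather than measured sizes, so the data establish no change beyond the scatter, only that this larger group, with its added six-membered aromatic ring of carbon only, is the one member of the set to return a number. The series still rests mostly on a ceiling: the limit of > 100000 nM in this assay, at which 2 of the 3 values shown sit.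

The compounds shown leave open whether the added six-membered ring or the attachment through the 2-yl rather than the 3-yl carbon accounts for the number in compound 3, and how large the true steps from compound 1 and compound 2 are. Also open, on these data alone, is how this position responds to a group of another kind, such as an amine, a carboxylic acid or a longer alkyl chain.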